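The source may report more compounds than this note shows. Statements on the series, on what has been measured and on what is new or still open speak of the compounds shown alone.

Compound 1 `COc1ccc(-c2cnc(NC(=O)c3cnc[nH]3)n2C)cc1` gives > 100000 nM in a toxicity assay on THP-1 cells (Homo sapiens) for inhibition; a higher number here means that more compound is tolerated, a lower number that less compound is tolerated; this value is a limit of the assay.
Compound 2 `Cn1c(-c2ccc(F)cc2)cnc1NC(=O)c1ccc(F)cc1` gives > 100000 nM in this assay; this value is also a limit.

Compound 1 stands at the upper limit of what this assay reports, and the same holds for compound 2, as shown by the limit of > 100000 nM in this assay, at which 2 of the 2 values shown sit. Among the measured compounds shown here, no step between measured compounds is available here. Compound 3 `COc1ccc(-c2cnc(NC(=O)c3cccc(F)c3)n2C)cc1` differs from compound 1 by 3-fluorophenyl in place of 1H-imidazol-5-yl on a carbonyl carbon. Since both measured compounds sit at the limit, no step beyond the scatter is expected in this assay, and the estimated a number no higher from compound 1 to compound 3 (the limit leaves the size open) reflects this. Compound 3 is therefore expected to give about 100000 nM, within a range of 40000 nM to 300000 nM.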

Compound 3, half-maximal cytotoxic concentration: > 100000 nM
Compound 3: no number, only a limit; the forecaster's own chance of this, stated with the estimate: 75%; the middle value lies on the limit itself.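

Among the compounds shown here, no step from compound 1 to compound 3 can be read in this assay, as compound 3 also stands at a limit: the limit of > 100000 nM in this assay, at which 3 of the 3 values shown sit. The compounds shown leave open how much of each is tolerated beyond that limit, and whether the exchange of groups changes it.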